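From 2-Bromophenyl to 3-Bromophenyl: A Step Among Limits

This account rests on a few compounds, and the source may have more. Where it says the series, first, only, none or still open, it means among the compounds named here.

- Compound 1 `c1ccc(Cn2ccc3nc(-c4ccccc4)nc-3c2)cc1`: > 100000 nM, a limit
- Compound 2 `Clc1ccc(Cn2ccc3nc(-c4ccccc4)nc-3c2)cc1`: > 100000 nM, a limit
- Compound 3 `Brc1ccccc1Cn1ccc2nc(-c3ccccc3)nc-2c1`: > 100000 nM, a limit

In an ADME assay on MDBK cells (Bos taurus) for cytotoxicity (on this read-out lower numbers stand for higher toxicity in this test and higher numbers for lower toxicity in this test), compound 3 gives > 100000 nM, which is a limit and not a number. It shares this position with the other two compounds: the limit of > 100000 nM in this assay, at which 3 of the 3 values shown sit. Compound 4 `Brc1cccc(Cn2ccc3nc(-c4ccccc4)nc-3c2)c1` is not yet measured, and the change from compound 3 is this: 3-bromophenyl in place of 2-bromophenyl on a saturated chain carbon bound to an aromatic nitrogen. For the measured compounds named here, three measured steps bear on it: a step that the two limits leave unreadable from compound 1 to compound 3, a step that the two limits leave unreadable from compound 2 to compound 3 and a step that the two limits leave unreadable from compound 1 to compound 2. None has a readable size, so none points in a direction. The expected change is a number no higher from compound 3 to compound 4 (the limit leaves the size open), with no step beyond the scatter and most likely another limit. The estimate for compound 4 is 100000 nM, expected within 50000 nM to 200000 nM.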

Compound 4, half-maximal cytotoxic concentration: 85000 nM
Estimate against measurement, compound 4: 1.2-fold (0.07 log units) above; the measured number falls inside the stated range.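

Compound 4, with 3-bromophenyl in place of 2-bromophenyl, is the only compound shown to give a number rather than a limit in this assay: the limit of > 100000 nM in this assay, at which 3 of the 4 values shown sit. This makes three steps readable: an at least 1.1-fold lower number from compound 3 to compound 4 (0.07 log units; that floor lies within the scatter), an at least 1.1-fold lower number from compound 2 to compound 4 (0.07 log units; that floor lies within the scatter) and an at least 1.1-fold lower number from compound 1 to compound 4 (0.07 log units; that floor lies within the scatter). Each is only a floor, the steps among the earlier compounds cannot be read, and so this change is not shown to matter.

As far as these compounds go, how far compounds 1, 2 and 3 lie past their limits stays open. So does what an amine or a carboxylic acid in place of the bromo group would give.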